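The compounds below may be only part of what the source reports. "The series", "measured", "known", "first", "only" and "open" are said of these compounds alone.

Among the measured compounds shown here, in an ADME assay on the whole organism (Rattus norvegicus) for pharmacokinetics, at a dose of 1 mg/kg by the intravenous route (on this read-out lower numbers stand for lower oral bioavailability and higher numbers for higher oral bioavailability), compound 1 (`Cc1ccc([C@H](C)NC(=O)Cn2nnc3ccccc3c2=O)cc1`) gives 27%, the lower of the two numbers measured so far, and compound 2 (`COc1cccc2nnn(CC(=O)N[C@@H](C)c3ccc(C)cc3)c(=O)c12`) gives 50%. Compound 3 (`COc1ccc2nnn(CC(=O)N[C@@H](C)c3ccc(C)cc3)c(=O)c2c1`) keeps the core of compound 1 and has methoxy in place of hydrogen on an aromatic carbon. The new group sits on the six-membered aromatic ring of carbon only, part of a fused system of two rings. For the measured compounds named here, the one measured step that bears on this is a number 23 percentage points higher from compound 1 to compound 2 (beyond the scatter), which is the same exchange with the methoxy at a different place on the ring. A single step cannot show how far its size carries over to another place, so a rise of smaller size is expected, and the estimated step is a number 11 percentage points higher from compound 1 to compound 3 (beyond the scatter). In this assay, compound 3 is expected to give 38%, with an estimated range from 20% to 58%.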

Compound 3, oral bioavailability: 2%
Beside the measured number, compound 3's estimate is 36 percentage points above it; the whole stated range lies above it.
By their numbers in this assay, from the lowest: compound 3; then compound 1; then compound 2.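

In this assay the exchange of hydrogen for methoxy does not keep one direction across the ring: here the step is a fall (a number 25 percentage points lower from compound 1 to compound 3 (beyond the scatter)), where the earlier step was a rise (a number 23 percentage points higher from compound 1 to compound 2 (beyond the scatter)). The sign of the step therefore depends on where the methoxy sits on the six-membered aromatic ring of carbon only, and at this place, meta to a fused ring and para to a fused ring, the exchange is a loss. No measurement at hand bears on what lies behind this reversal.

Going by these compounds, whether the fall belongs to methoxy itself or to any group at this place stays open, and fluorine, a hydroxy group or an amine there would separate the two. On these data alone, how the remaining aromatic carbons of that ring respond to methoxy also stays open.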